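Adding a methoxy group to the pyrazole-side aryl ring

The compounds below may be only part of what the source reports. "The series", "measured", "known", "first", "only" and "open" are said of these compounds alone.

Three compounds sharing a pyrazole core linked through a propenone chain to an aromatic ring have been measured in a functional assay on NCI-H226 cells (Homo sapiens) for inhibition, read by sulforhodamine B assay, with a stated time of 48 h; on this read-out higher numbers stand for weaker inhibition of growth and lower numbers for stronger inhibition of growth. Compound 1, `COc1ccc(-c2cc(/C=C/C(=O)c3ccc(N)cc3)[nH]n2)cc1`, gives 2000 nM. Compound 2, `COc1cc(-c2cc(/C=C/C(=O)c3ccc(Cl)c(Cl)c3)[nH]n2)cc(OC)c1OC`, gives 18600 nM. Compound 3, `COc1ccc(C(=O)/C=C/c2cc(-c3cc(OC)c(OC)c(OC)c3)n[nH]2)cc1OC`, gives 1690 nM. Among these, compound 1 stands second highest; its number sits close to that of compound 3, a gap within the scatter, and well apart from that of compound 2, a gap beyond the scatter. For the measured compounds named here, the one step between measured compounds that differ in a single place is an 11-fold lower number from compound 2 to compound 3 (1.04 log units; beyond the scatter), which touches the ring on the carbonyl carbon.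

Compound 4, `COc1ccc(-c2cc(/C=C/C(=O)c3ccc(N)cc3)[nH]n2)cc1OC`, differs from compound 1 by methoxy in place of hydrogen on an aromatic carbon. Going by the values given here, this change sits on the other aromatic ring, the one attached to the pyrazole core, so no measured step speaks to it directly. Among the compounds with values here, the only guidance is that compound 1 and compound 3, which carry one and three methoxy groups on that ring, give numbers within the scatter of each other. A step of no size beyond the scatter is therefore expected, a 1.1-fold lower number from compound 1 to compound 4 (0.05 log units; within the scatter). Compound 4 is estimated at 1800 nM, with a range from 800 nM to 4500 nM.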

Compound 4, concentration for 50% growth inhibition: 2320 nM
Compound 4: the middle estimate sits 1.3-fold (0.11 log units) below what was measured; the measured number falls inside the stated range.
By their numbers in this assay, from the lowest: compounds 3, 1 and 4 (each within the scatter of the next); then compound 2.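

For the compounds shown here, this is the first measured step on the aromatic ring attached to the shared core: methoxy in place of hydrogen, on an aromatic carbon ortho to a methoxy group and meta to a large group, gives a 1.2-fold higher number from compound 1 to compound 4 (0.06 log units; within the scatter) in this assay. With the aminophenyl ring on the carbonyl carbon held fixed, this position therefore accepts a second methoxy group with no shift that can be told apart from the usual scatter of this assay. Unlike an 11-fold lower number from compound 2 to compound 3 (1.04 log units; beyond the scatter), a step on the ring at the carbonyl carbon that lies beyond the scatter, this change on the other ring stays within it. No separate measurement bears on this result.

Going by these compounds, whether an ethoxy group, a longer alkoxy chain, an amine or a carboxylic acid at this same position would move the number beyond the scatter remains open. On these data alone, it is also open whether the same methoxy change would stay as small with a different ring on the carbonyl carbon, such as the dichlorophenyl ring of compound 2.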